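Propoxy to allyloxy: working notes on a small series

The source may report more compounds than this note shows. Statements on the series, on what has been measured and on what is new or still open speak of the compounds shown alone.

Measured so far in a functional assay on MCF7 cells (Homo sapiens) for inhibition, read by MTT assay, with a stated time of 72 h; on this read-out lower numbers stand for stronger inhibition and higher numbers for weaker inhibition:
compound 1 `CCCO[C@@H]1C=CC(=O)[C@@H](CO)O1`: 18300 nM
compound 2 `CCO[C@@H]1C=CC(=O)[C@@H](CO)O1`: "not determined" (no result reported)
compound 3 `C#CCO[C@@H]1C=CC(=O)[C@@H](CO)O1`: 10400 nM

Going by the values given here, compound 1 and compound 3 supply the only two numbers, and they lie within the scatter of each other. Compound 2 has no result, so it offers no comparison. Compound 1 therefore serves as a reference point in the series, not as a clear extreme.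

The next compound to be tested is compound 4 `C=CCO[C@@H]1C=CC(=O)[C@@H](CO)O1`. It differs from compound 1 as follows: vinyl in place of ethyl on a saturated chain carbon bound to an oxygen on a saturated carbon. Seen one bond further out, the same change turns propoxy into allyloxy.

Among the compounds with values here, one measured step bears on this change, the replacement of ethyl by ethynyl at the same place: a 1.8-fold lower number from compound 1 to compound 3 (0.25 log units; within the scatter). Within the data shown here, that single step stayed within the scatter, and no measured compound yet carries vinyl at this place. No step beyond the scatter is therefore expected in this assay, and no direction can be firmly expected.

The expected step is a 1.3-fold lower number from compound 1 to compound 4 (0.12 log units; within the scatter). For compound 4 the estimated value is 14000 nM, with an expected range from 7500 nM to 27000 nM.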

Compound 4, half-maximal inhibitory concentration: 16300 nM
For compound 4 the middle estimate is 1.2-fold (0.07 log units) below the measured one, within the range that was stated.
By their numbers in this assay, from the lowest: compounds 3, 4 and 1 (each within the scatter of the next).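

In this assay, vinyl in place of ethyl on a saturated chain carbon bound to an oxygen on a saturated carbon gives a 1.1-fold lower number from compound 1 to compound 4 (0.05 log units; within the scatter), and vinyl in place of ethynyl at the same place gives a 1.6-fold higher number from compound 3 to compound 4 (0.20 log units; within the scatter). Where the earlier numbers offered a single replacement at this place, ethyl, vinyl and ethynyl now form a set of three whose values all lie within the scatter of one another, so none of these changes separates the compounds on this read-out. No measured evidence on the cause of this accompanies the values.

Compound 2 has no result, and steps to it cannot be read. Going by these compounds, whether this place tolerates a wider change stays open: the numbers cover only the three groups above, and a longer chain, a phenyl ring or an amine at the same place could still give a step beyond the scatter or leave the series as level as it stands now.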